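A few compounds are considered here, and "the series" means these few. Any claim that something is new, unique, unknown or untested is made for them only; others in the source may bear on it.

The measured compounds:
compound 1, `Cc1ccc(NC(=O)C(=O)NC(c2nc(C)c(CCO)s2)C2CCCCN2)cc1F`, in an ADME assay on MT2 cells (Homo sapiens) for cytotoxicity, read by XTT assay, with a stated time of 4 days; a higher number here means that more compound is tolerated, a lower number that less compound is tolerated: 85000 nM
compound 2, `Cc1ccc(NC(=O)C(=O)NC(c2nc(C)c(CO)s2)C2CCCCN2)cc1F`, in this assay: > 88000 nM
compound 3, `Cc1nc(C(NC(=O)C(=O)NC2CCCCCC2)C2CCCCN2)sc1CCO`, in this assay: 60000 nM

The value of compound 2 in this assay is a limit, (the limit of > 88000 nM in this assay, at which 1 of the 3 values shown sits). Compound 1 and compound 2 differ by hydroxy in place of hydroxymethyl on a saturated chain carbon bound to an aromatic carbon; that change gave an at least 1.0-fold higher number from compound 1 to compound 2 (0.01 log units; that floor lies within the scatter). Compound 4, `Cc1nc(C(NC(=O)C(=O)NC2CCCCCC2)C2CCCCN2)sc1CO`, is not yet measured; it differs from compound 3 by hydroxy in place of hydroxymethyl on a saturated chain carbon bound to an aromatic carbon, the same change at the same place. The cores of compound 1 and compound 3 differ by cycloheptyl in place of 3-fluoro-4-methylphenyl on an amide-type nitrogen, with a 1.4-fold lower number from compound 1 to compound 3 (0.15 log units; within the scatter). Because the earlier step of an at least 1.0-fold higher number from compound 1 to compound 2 (0.01 log units; that floor lies within the scatter) ends at a limit and the core change a 1.4-fold lower number from compound 1 to compound 3 (0.15 log units; within the scatter) is within the scatter, compound 4 is expected to show a step of about a 1.2-fold higher number from compound 3 to compound 4 (0.07 log units; within the scatter). Compound 4 is estimated at 70000 nM in this assay, between 40000 nM and 110000 nM.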

Compound 4, half-maximal cytotoxic concentration: > 90000 nM
Compound 4: only a limit was reported (the forecaster's own chance of this, stated with the estimate: 40%); middle value at least 1.2-fold (0.10 log units) from the limit.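

In this assay compound 4 gives > 90000 nM, which is a limit and not a number. On the core of compound 3, going from 2-hydroxyethyl to hydroxymethyl gave an at least 1.5-fold higher number from compound 3 to compound 4 (0.17 log units; that floor lies within the scatter). The result does not contradict carrying this change from one core to another, but it does not show that the change has the same size on both cores: the same change on two cores in this assay, an at least 1.0-fold higher number (0.01 log units; that floor lies within the scatter) from compound 1 to compound 2 and an at least 1.5-fold higher number (0.17 log units; that floor lies within the scatter) from compound 3 to compound 4; the limit leaves it open whether they differ

Both compound 2 and compound 4 carry limits, so the step between them cannot be read. The compounds shown also leave open how a longer chain or an amine at this place would read in this assay.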